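The compounds below may be only part of what the source reports. "The series", "measured", "known", "first", "only" and "open" are said of these compounds alone.

Measured compounds:
- compound 1, `C=CCOc1cc(OC)c(C(=O)/C=C/c2ccccc2F)c(OCC=C)c1`: 16300 nM
- compound 2, `C=CCOc1cc(OC)c(C(=O)/C=C/c2ccc(O)cc2)c(OCC=C)c1`: 76400 nM
- compound 3, `C=CCOc1cc(OC)c(C(=O)/C=C/c2cc(OCC=C)c(Br)c(OCC=C)c2)c(OCC=C)c1`: 96300 nM

All three were tested in an ADME assay on Vero cells (Chlorocebus sabaeus) for cytotoxicity, read by MTT assay; on this read-out lower numbers stand for stronger inhibition and higher numbers for weaker inhibition. Compound 2 gives the second highest of the three numbers; its value and that of compound 3 lie within the scatter of each other, so no order can be read between them, while compound 1 sits clearly apart, with a 4.7-fold higher number from compound 1 to compound 2 (0.67 log units; beyond the scatter).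

Compound 4, `C=CCOc1cc(OC)c(C(=O)/C=C/c2ccccn2)c(OCC=C)c1`, has not yet been measured. It differs from compound 2 in a single place: pyridin-2-yl in place of 4-hydroxyphenyl on a double-bonded chain carbon bound to a double-bonded chain carbon.

Only one measured step bears on this change, the one from compound 1 to compound 2, which also swapped the ring at the same place and was modest, as shown by a 4.7-fold higher number from compound 1 to compound 2 (0.67 log units; beyond the scatter). Since removing the hydroxyl-bearing ring reverses part of that swap, a modest step toward a lower number, beyond the scatter, is expected for compound 4, namely a 1.9-fold lower number from compound 2 to compound 4 (0.28 log units; within the scatter). Compound 4 is therefore estimated at 40000 nM, within a range from 12000 nM to 120000 nM.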

Compound 4, half-maximal inhibitory concentration: 2800 nM
Estimate against measurement, compound 4: 14-fold (1.15 log units) above; measured number below the stated range.
By their numbers in this assay, from the lowest: compound 4; then compound 1; then compounds 2 and 3 (each within the scatter of the next).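

In this assay, going by these compounds alone, this place on the chain proves far more sensitive than the earlier compounds showed, with a 27-fold lower number from compound 2 to compound 4 (1.44 log units; beyond the scatter) and with a 5.8-fold lower number from compound 1 to compound 4 (0.77 log units; beyond the scatter) as well. Within the data shown here, both steps lie beyond the scatter and both end at pyridin-2-yl, so a ring holding a nitrogen atom moves the number toward stronger inhibition, well past what the one swap between carbon-only rings had suggested. Nothing at hand accounts for this shift.

The compounds shown leave open whether the nitrogen atom itself goes with the lower number, since a plain phenyl ring with no added group is not among them. They also leave open how pyridin-3-yl or pyridin-4-yl would compare with pyridin-2-yl at this same place.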